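Swapping the amine-borne group in compound 2

A few compounds are considered here, and "the series" means these few. Any claim that something is new, unique, unknown or untested is made for them only; others in the source may bear on it.

Among the measured compounds shown here, compound 2 `COc1ccc2nccc(CC[C@H]3CC[C@H](NCc4ccc5c(n4)NC(=O)CO5)CC3)c2c1` is one of three compounds measured in an ADME assay on K562 cells (Homo sapiens) for antiproliferative activity; on this read-out lower numbers stand for stronger inhibition and higher numbers for weaker inhibition; in this assay compound 2 gives 12000 nM. Compound 3 `COc1ccc2nccc(CC[C@H]3OC[C@H](NCc4ccc(Cl)cc4)CO3)c2c1` gives 12000 nM in this assay, which is level with compound 2 at the digits shown. Compound 1 `COc1ccc2nccc(CC[C@H]3OC[C@H](NCc4cc5c(cn4)OCCC5)CO3)c2c1` gives 32000 nM in this assay, and compound 2 stands at a lower number than compound 1, a gap beyond the scatter. Together compound 2 and compound 3 are the lowest of the three numbers.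

Compound 4 `COc1ccc2nccc(CC[C@H]3CC[C@H](NCc4cc5c(cn4)OCCO5)CC3)c2c1` differs from compound 2 by a group of 10 heavy atoms (7 carbon, 1 nitrogen, 2 oxygen; one six-membered non-aromatic ring with 2 hetero atoms, one six-membered aromatic ring with 1 hetero atom) in place of a group of 11 heavy atoms (7 carbon, 2 nitrogen, 2 oxygen; one six-membered non-aromatic ring with 2 hetero atoms, one six-membered aromatic ring with 1 hetero atom), on a saturated chain carbon bound to an amine nitrogen. The group that leaves carries 1 hydrogen-bond donor; the group that enters carries none. For the measured compounds named here, no measured step changes this particular pair of groups. Going by the values given here, the one measured step at the same place, a 2.7-fold lower number from compound 1 to compound 3 (0.43 log units; beyond the scatter), shows that swapping the amine-borne group moves the number only modestly. A step of similar size at most is therefore expected here, with no clear direction; the expected step of a 1.3-fold higher number from compound 2 to compound 4 (0.10 log units; within the scatter) stays within the scatter. Compound 4 is estimated at 15000 nM, with a range from 6000 nM to 40000 nM.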

Compound 4, half-maximal inhibitory concentration: 7500 nM
Compound 4: middle estimate off by 2.0-fold (0.30 log units), on the high side; measured number inside the range.
By their numbers in this assay, from the lowest: compounds 4, 2 and 3 (each within the scatter of the next); then compound 1.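

In this assay, among the compounds shown here, the exchange on the saturated chain carbon bound to an amine nitrogen gives a 1.6-fold lower number from compound 2 to compound 4 (0.20 log units; within the scatter), so this pair adds a step within the scatter to the one step at this place that lies beyond it, a 2.7-fold lower number from compound 1 to compound 3 (0.43 log units; beyond the scatter). The group that leaves carries 1 hydrogen-bond donor and the group that enters carries 0, and on this pair that difference does not separate the two numbers beyond the scatter. Nothing on hand explains this result.

Going by these compounds, whether the group of compound 4 would behave the same way on the core of compound 1 remains open. Also open, on these data alone, is whether a group of another kind at this place, such as a carboxylic acid or a longer chain, would move the number beyond the scatter.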